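The source may hold more compounds than are shown below. What is called first, only, known or untested is meant among the compounds shown, and "the series" means these compounds.

Compound 1 `CCN(CC)CCNC(=O)c1ccc(C(CC)(CC)c2ccc(OCCC(O)(CC)CC)c(C)c2)n1CC` carries a 2-(diethylamino)ethyl group on its amide nitrogen, and in a functional assay on MCF7 cells (Homo sapiens) for antiproliferative activity, read by MTT assay, with a stated time of 48 h (a lower number here means a stronger inhibitor, a higher number a weaker inhibitor), compound 1 gives 550 nM. Compound 2 `CCn1c(C(=O)NCC#N)ccc1C(CC)(CC)c1ccc(OCCC(O)(CC)CC)c(C)c1` gives only a limit of this assay, namely > 50000 nM. Compound 3 `CCn1c(C(=O)Nc2cccc(C(F)(F)F)c2)ccc1C(CC)(CC)c1ccc(OCCC(O)(CC)CC)c(C)c1` likewise gives only a limit, > 50000 nM. Both steps of an at least 90-fold higher number from compound 1 to compound 2 (1.95 log units; beyond the scatter) and an at least 90-fold higher number from compound 1 to compound 3 (1.95 log units; beyond the scatter) are large, and compound 2 stands at the limit of > 50000 nM in this assay, at which 2 of the 3 values shown sit. The step that the two limits leave unreadable from compound 2 to compound 3 cannot be read. Compound 4 `CCOC(=O)CN(C)C(=O)c1ccc(C(CC)(CC)c2ccc(OCCC(O)(CC)CC)c(C)c2)n1CC` differs from compound 2 by ((ethoxycarbonyl)methyl)(methyl)amino in place of (cyanomethyl)amino on a carbonyl carbon. For the measured compounds named here, no measured step shows this kind of change, and both amides lacking the 2-(diethylamino)ethyl group sit at the limit, so the expected step is an at least 1.2-fold lower number from compound 2 to compound 4 (0.09 log units; that floor lies within the scatter), with weak inhibition remaining likely. Compound 4 is therefore estimated at 40000 nM, between 10000 nM and 100000 nM.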

Compound 4, half-maximal inhibitory concentration: 3210 nM
For compound 4 the middle estimate is 12-fold (1.10 log units) above the measured one, and the stated range ends above it.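

The ((ethoxycarbonyl)methyl)(methyl)amino group on this carbonyl carbon gives an at least 15-fold lower number from compound 2 to compound 4 (1.19 log units; beyond the scatter) and an at least 15-fold lower number from compound 3 to compound 4 (1.19 log units; beyond the scatter). Compound 4 lacks the 2-(diethylamino)ethyl group yet has a measurable value in this assay, so activity among these amides does not depend on that group alone. That group still gives the lower number, with a 5.8-fold higher number from compound 1 to compound 4 (0.77 log units; beyond the scatter).

Compound 4 both replaces the amide hydrogen with methyl and brings in the ester, and the compounds shown cannot separate these two changes. As far as these compounds go, what a carboxylic acid in place of the ethyl ester would give also stays open.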